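Notes on a pyrazolopyrimidine-type series against the activin receptor

The source may hold more compounds than are shown below. What is called first, only, known or untested is meant among the compounds shown, and "the series" means these compounds.

Three compounds of the shared core have numbers in an assay on isolated protein for inhibition of activin receptor type-2A (Homo sapiens), read by 33P incorporation, with a stated time of 20 min, in the presence of a further agent that is not named here; on this read-out higher numbers stand for weaker inhibition and lower numbers for stronger inhibition. Compound 1 `CNc1nc2c(-c3ccnc(OC)c3)cnn2cc1C` gives 1300 nM. Compound 2 `CCc1nc2c(-c3ccnc(OC)c3)cnn2cc1OC` gives 960 nM. Compound 3 `COc1cn2ncc(-c3ccnc(OC(C)C)c3)c2nc1-c1cnn(C)c1` gives 2300 nM.

On these numbers compound 2 has the lowest value of the three. Its gap to compound 1 lies within the scatter, so no order between compound 2 and compound 1 is claimed. Its gap to compound 3 lies beyond the scatter, with compound 3 at the higher number.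

Compound 4 `COc1cc(-c2cnn3cc(OC)c(N(C)C)nc23)ccn1` is not yet measured in this assay. It differs from compound 2 in one place: dimethylamino in place of ethyl on an aromatic carbon, on a six-membered aromatic ring with two nitrogen atoms, next to the ring nitrogen and ortho to a methoxy group.

For the measured compounds named here, no step between measured compounds is known for this exchange. Compound 1, which carries methylamino at the same place of the core, gives 1300 nM, and compound 2 gives 960 nM; these two stand within the scatter of each other, and the further difference between them (methyl against methoxy) is not isolated. The expectation is therefore a step from compound 2 to compound 4 of a 1.1-fold higher number from compound 2 to compound 4 (0.06 log units; within the scatter), not beyond the scatter. Compound 4 is estimated at 1100 nM in this assay, with a range from 400 nM to 3200 nM.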

Compound 4, half-maximal inhibitory concentration: 3000 nM
The estimate for compound 4 lay 2.7-fold (0.44 log units) below the measured number; the range from low to high includes it.
By their numbers in this assay, from the lowest: compounds 2, 1, 3 and 4 (each within the scatter of the next, the first and the last beyond it).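

In this assay, dimethylamino in place of ethyl on this aromatic carbon, ortho to a methoxy group, gives a 3.1-fold higher number from compound 2 to compound 4 (0.49 log units; beyond the scatter). For the compounds shown here, this is the first exchange that can be read at a single place, and it shows that the position is not indifferent to the group it carries: with the rest of the compound held constant, the step is modest but beyond the scatter. No measurement shown accounts for the size or direction of this step, and the single pair cannot separate the entering nitrogen from the extra heavy atom in the group.

On these data alone, what remains open is whether the higher number follows the nitrogen attached to the aromatic carbon or the size of the group, a question that a propyl chain or a free amino group at this place, with the methoxy group kept, would help to settle. Also open, as far as these compounds go, is whether the same step would hold with the other substituents of the shared core, since this exchange rests on one pair.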